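The source may hold more compounds than are shown below. What is called first, only, known or untested is meant among the compounds shown, and "the series" means these compounds.

Compound 1 `COc1cc(OCc2cccc(C#N)c2)c2cc(-c3cn4nc(OC)sc4n3)oc2c1` gives 0.98 nM in a functional assay on HEK293 cells for antagonist activity at proteinase-activated receptor 4 (Homo sapiens), read by FLIPR and calcium flux, with a stated time of 30 min; a higher number here means a weaker inhibitor, a lower number a stronger inhibitor.
Compound 2 `COc1nn2cc(-c3cc4cccc(OC)c4o3)nc2s1` gives 2.8 nM in this assay.

Of these two numbers, compound 1 has the lower one, and its gap to compound 2 is wider than the usual scatter of repeat measurements, so compound 1 is the stronger inhibitor of the pair. Among the measured compounds shown here, no two measured compounds here differ in just one place, so no step size can be read directly from measured data.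

Compound 3 `COc1cc(OCc2cccc(Sc3ccccc3)c2)c2cc(-c3cn4nc(OC)sc4n3)oc2c1` is built from compound 1 by a single change: phenylsulfanyl in place of cyano on an aromatic carbon. The cyano leaves and a phenylsulfanyl enters on the same aromatic carbon, meta to a large group. Nothing measured here shows how such a swap moves the readout in this assay, so the expectation rests on the change itself. The expected step is a 2.2-fold higher number from compound 1 to compound 3 (0.35 log units; beyond the scatter), a modest move toward a somewhat higher number. Compound 3 is therefore estimated at 2.2 nM, with a likely range from 0.5 nM to 9 nM.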

Compound 3, half-maximal inhibitory concentration: 0.89 nM
Compound 3: the middle estimate sits 2.5-fold (0.39 log units) above what was measured; the range from low to high includes it.
By their numbers in this assay, from the lowest: compounds 3 and 1 (each within the scatter of the next); then compound 2.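

In this assay putting phenylsulfanyl in place of cyano on this aromatic carbon, meta to a large group, gives a step (a 1.1-fold lower number from compound 1 to compound 3 (0.04 log units; within the scatter)), so the two compounds cannot be told apart by their numbers. This position therefore holds either the small cyano or a much larger group that brings a six-membered aromatic ring of carbon only, with no measurable cost in this read-out, and the triple bond of the cyano is not required for a number this low. Nothing available here accounts for why two such different groups give matching numbers.

The compounds shown leave open whether this tolerance extends to groups of a different kind at the same carbon, such as an amine or a carboxylic acid, which would test more than size alone. They also leave open whether the sulfur itself matters, which a phenoxy group would test, and whether the added ring could sit further out on a longer chain without the number rising beyond the scatter.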